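The compounds below may be only part of what the source reports. "The series", "measured", "known", "first", "only" and "open" are said of these compounds alone.

Measured in a functional assay on the whole organism for antagonist activity, with Mus musculus as the target, in the maximal electroshock model; a lower number here means that less compound is needed, a higher number that more compound is needed for the effect:
Compound 1 `COC(=O)NC1=NC(c2ccccc2C)CN1C`: 68 mg/kg
Compound 2 `COC(=O)NC1=NC(c2ccccc2F)CN1C`: 74 mg/kg

Compound 2, at 74 mg/kg, cannot be told apart from compound 1. For the measured compounds named here, the only measured step, a 1.1-fold higher number from compound 1 to compound 2 (0.04 log units; within the scatter), is fluoro in place of methyl on an aromatic carbon, and it stays within the scatter.

Compound 3 `CCCOC(=O)NC1=NC(c2ccccc2F)CN1C` keeps the fluoro group of compound 2 and alters a different part of the molecule, turning methoxycarbonyl into propoxycarbonyl. This is ethyl in place of hydrogen on a saturated chain carbon bound to an oxygen next to a carbonyl group.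

Going by the values given here, the measured step sits at another place on the molecule, and no measured pair changes this chain, so it offers only weak guidance and no direction can be read from it. In this assay, the expectation is therefore no step beyond the scatter, although a real shift either way remains possible. The estimated step runs a 1.1-fold lower number from compound 2 to compound 3 (0.02 log units; within the scatter). Compound 3 is estimated at 70 mg/kg, with an expected range from 30 mg/kg to 160 mg/kg.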

Compound 3, dose for half-maximal effect: 23 mg/kg
For compound 3 the middle estimate is 3.0-fold (0.48 log units) above the measured one; measured number below the stated range.
By their numbers in this assay, from the lowest: compound 3; then compounds 1 and 2 (each within the scatter of the next).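

In this assay, this end of the molecule turns out to be sensitive: replacing methoxycarbonyl with propoxycarbonyl gives a 3.2-fold lower number from compound 2 to compound 3 (0.51 log units; beyond the scatter), so less compound is needed for the effect. The exchange of methyl for fluoro on an aromatic carbon gave only a 1.1-fold higher number from compound 1 to compound 2 (0.04 log units; within the scatter), which makes adding ethyl at the saturated chain carbon bound to the oxygen the only change shown that moves the number beyond the usual scatter. The data offer no measurement that could explain the shift, so its cause remains unknown.

The compounds shown leave open whether the number keeps falling as the chain grows, since a single pair cannot reveal a trend: ethoxycarbonyl could land between compound 2 and compound 3, while a longer chain such as butoxycarbonyl, a branched one such as isopropoxycarbonyl or a chain ending in an amine could continue the shift, show no further change or reverse it. On these data alone, it is also open whether propoxycarbonyl would bring a similar step on a compound carrying the methyl group of compound 1 rather than fluoro.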